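The source may hold more compounds than are shown below. What is called first, only, known or untested is meant among the compounds shown, and "the series" means these compounds.

Measured so far in an ADME assay on LLC-PK1 cells (Sus scrofa) for permeability; a higher number here means that the compound crosses the layer faster, a lower number that the compound crosses the layer more slowly:
compound 1 `COc1ccccc1C(=O)NC(=O)Nc1ccc(-c2nccs2)c(C(F)(F)F)c1` gives 12 10^-6 cm/s
compound 2 `COc1ccccc1C(=O)NC(=O)Nc1ccc(N2CCCCC2)c(C(F)(F)F)c1` gives < 1 10^-6 cm/s, a limit of the assay
compound 3 `COc1ccccc1C(=O)NC(=O)Nc1ccc(OCC(F)(F)F)c(C(F)(F)F)c1` gives < 1 10^-6 cm/s, a limit of the assay

Compound 3 stands at the lower end of what the assay reports: its value is a limit and not a number. The same holds for compound 2, as the limit of < 1 10^-6 cm/s in this assay, at which 2 of the 3 values shown sit. Against compound 1 the steps are readable: an at least 12-fold lower number from compound 1 to compound 3 (1.07 log units; beyond the scatter), and in the same way an at least 12-fold lower number from compound 1 to compound 2 (1.07 log units; beyond the scatter). Between compound 2 and compound 3 a step that the two limits leave unreadable from compound 2 to compound 3.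

Compound 4 `COc1ccccc1C(=O)NC(=O)Nc1ccc(C(C)C)c(C(F)(F)F)c1` is not yet measured. The change from compound 3 is isopropyl in place of 2,2,2-trifluoroethoxy on an aromatic carbon. Among the compounds with values here, none of the measured steps involves an isopropyl group, and both readable steps run from the 1,3-thiazol-2-yl compound down to the limit, so they set no direction for this change. Within the data shown here, what the numbers show is only that compound 3 sits at the limit; a readable number for compound 4 would therefore be a rise, an unreadable one no change. On that basis compound 4 is expected at 3 10^-6 cm/s, within 1 10^-6 cm/s to 10 10^-6 cm/s. The step this estimate means is expected to be an at least 3.0-fold higher number from compound 3 to compound 4 (0.47 log units; beyond the scatter), with a fair chance that compound 4 also returns only a limit.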

Compound 4, apparent permeability in the LLC-PK1 assay: 2.1 10^-6 cm/s
For compound 4 the middle estimate is 1.4-fold (0.15 log units) above the measured one, and the stated range covers the measured number.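

At this position, on an aromatic carbon ortho to a trifluoromethyl group and para to a large group, isopropyl gives a readable number in the LLC-PK1 assay where the 2,2,2-trifluoroethoxy and piperidin-1-yl groups do not, with an at least 2.1-fold higher number from compound 3 to compound 4 (0.32 log units; beyond the scatter) and an at least 2.1-fold higher number from compound 2 to compound 4 (0.32 log units; beyond the scatter), yet the number stays well short of that of the 1,3-thiazol-2-yl group, with a 5.7-fold lower number from compound 1 to compound 4 (0.76 log units; beyond the scatter). In a physicochemical assay for solubility (on this read-out lower numbers stand for lower solubility and higher numbers for higher solubility), compound 3 gives < 1 ug/mL, a limit of the assay. In the physicochemical assay compound 4 gives < 1 ug/mL, again a limit of the assay, and steps that join two limits cannot be read.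

The compounds shown leave open whether a longer carbon chain, a cyclopropyl group or a carboxylic acid at this position would carry the number in the LLC-PK1 assay further up or return it to the limit. They also leave open whether any group here, for example a primary amine, would bring a readable number in the physicochemical assay.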